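Replacing (3-chlorophenyl)amino: expected cytotoxicity of compound 3

This account rests on a few compounds, and the source may have more. Where it says the series, first, only, none or still open, it means among the compounds named here.

Compound 1 `COc1ccc(-c2nc(CNc3cccc(Cl)c3)nc3ccsc23)cn1`: > 50000 nM
Compound 2 `COc1ccc(-c2nc(C(C)(C)S(=O)(=O)c3cccc(Cl)c3)nc3ccsc23)cn1`: > 50000 nM

Of the compounds shown here, two have so far been tested in an ADME assay on cells (Homo sapiens) for cytotoxicity, read by resazurin assay, with a stated time of 5 days; on this read-out higher numbers stand for lower toxicity in this test and lower numbers for higher toxicity in this test. Compound 1 gives > 50000 nM, which is a limit of the assay rather than a number. Compound 2 likewise gives > 50000 nM, again a limit. Compound 1 therefore stands at the limit of > 50000 nM in this assay, at which 2 of the 2 values shown sit, and nothing in these readings separates it from compound 2. Compound 3 `COc1ccc(-c2nc(CSc3cc(C)cc(C)c3)nc3ccsc23)cn1` has not yet been measured. It differs from compound 1 in a single place: (3,5-dimethylphenyl)sulfanyl in place of (3-chlorophenyl)amino on a saturated chain carbon bound to an aromatic carbon. Going by the values given here, no measured pair shows what a change of this kind does, so any expectation can rest only on the limits already seen. A step from compound 1 to compound 3 of about a step that the limit leaves unreadable from compound 1 to compound 3 is expected, that is, none beyond the scatter, because compound 1 already sits at the limit of > 50000 nM in this assay, at which 2 of the 2 values shown sit. Compound 3 is thus estimated to give roughly 60000 nM, within 20000 nM to 200000 nM, and will most probably be reported once more as a limit.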

Compound 3, half-maximal cytotoxic concentration: > 50000 nM
Compound 3: only a limit was reported (the forecaster's own chance of this, stated with the estimate: 75%); the middle value is on the limit's open side.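

No step from compound 1 to compound 3 can be read, because both give a limit rather than a number: the limit of > 50000 nM in this assay, at which 3 of the 3 values shown sit.

The compounds shown leave open whether (3,5-dimethylphenyl)sulfanyl in place of (3-chlorophenyl)amino changes the cytotoxicity at all, and by how much.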